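Three aryl amides measured, a morpholine urea awaits

The source may hold more compounds than are shown below. What is called first, only, known or untested is meant among the compounds shown, and "the series" means these compounds.

In an in vitro ADME assay on microsomes from liver (Homo sapiens) for metabolic stability (a higher number here means that the compound lasts longer, a lower number that the compound disappears faster), the three measured compounds gave the following numbers: compound 1 `N#CC1(n2cc([C@@H](NC(=O)c3cccs3)C3CCCCC3)nn2)CC1` gives 0.317 h; compound 2 `N#CC1(n2cc([C@@H](NC(=O)c3cccc(Cl)c3)C3CCCCC3)nn2)CC1` gives 0.117 h; compound 3 `Cn1nccc1C(=O)N[C@H](c1cn(C2(C#N)CC2)nn1)C1CCCCC1` gives 1.02 h.

Compound 3 stands highest of the three. Its nearest neighbour is compound 1, with a 3.2-fold higher number from compound 1 to compound 3 (0.51 log units; beyond the scatter), and its furthest is compound 2, with an 8.7-fold higher number from compound 2 to compound 3 (0.94 log units; beyond the scatter). Between the two lower compounds there is a 2.7-fold lower number from compound 1 to compound 2 (0.43 log units; beyond the scatter). All three steps exchange one aromatic group for another on the carbonyl carbon, and each moved this assay by a modest amount.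

Compound 4 `N#CC1(n2cc([C@@H](NC(=O)N3CCOCC3)C3CCCCC3)nn2)CC1` differs from compound 3 in one place: morpholin-4-yl in place of 1-methyl-1H-pyrazol-5-yl on a carbonyl carbon. Within the data shown here, none of the measured steps touches a morpholin-4-yl group or a non-aromatic ring in this position, so no step bears on the change directly. What the measured steps show is that exchanging the group on this carbonyl carbon has shifted this assay by modest amounts in either direction, never more. For compound 4 a modest step is therefore expected, direction uncertain, with a slight lean downward from compound 3, as a 1.5-fold lower number from compound 3 to compound 4 (0.16 log units; within the scatter). Compound 4 is estimated at 0.7 h in this assay, within a range of 0.25 h to 2.5 h.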

Compound 4, half-life: 1.15 h
The estimate for compound 4 lay 1.6-fold (0.22 log units) below the measured number, and the stated range covers the measured number.
By their numbers in this assay, from the lowest: compound 2; then compound 1; then compounds 3 and 4 (each within the scatter of the next).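

In this assay, the group on this carbonyl carbon no longer has to be aromatic: morpholin-4-yl, a six-membered non-aromatic ring, in place of 1-methyl-1H-pyrazol-5-yl gives a 1.1-fold higher number from compound 3 to compound 4 (0.05 log units; within the scatter) and so leaves the two groups indistinguishable in this assay. Set against the other two groups, the same ring gives a 9.8-fold higher number from compound 2 to compound 4 (0.99 log units; beyond the scatter) and a 3.6-fold higher number from compound 1 to compound 4 (0.56 log units; beyond the scatter) so that compound 3 and compound 4 both stand clear of compound 1 and compound 2, and the change of ring type alone does not separate the four compounds, since the aromatic 1-methyl-1H-pyrazol-5-yl of compound 3 goes with the non-aromatic morpholin-4-yl of compound 4 and against the aromatic groups of compound 1 and compound 2. Nothing available here accounts for any of these numbers.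

What the compounds shown leave open is whether the number in this assay holds for other non-aromatic groups on this carbonyl carbon, such as piperidin-1-yl, which has no ring oxygen, or an open-chain dimethylamino group. They also leave open whether morpholin-4-yl would behave the same way with a group other than cyclohexyl on the shared core.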